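This account rests on a few compounds, and the source may have more. Where it says the series, first, only, none or still open, it means among the compounds named here.

Measured compounds:
compound 1, `C[C@H](NC(=O)CN(c1nc(Cl)nc2[nH]cnc12)C1CC1)C(=O)OCc1ccccc1` — 41.2%
compound 2, `C[C@H](NC(=O)CN(c1ncnc2c1ncn2C1CCCCO1)C1CC1)C(=O)OCc1ccccc1` — 55.9%

In a functional assay on the whole organism (Tail, strain ICR) with Mus musculus as the target, in the tail flick test, with a stated time of 30 min, at a dose of 25 umol/kg by the oral route (a lower number here means a weaker effect, a higher number a stronger effect of the compound at the dose given), compound 1 gives 41.2%. In this assay compound 2 gives 55.9%, and compound 1 therefore stands lowest of the two numbers, with compound 2 higher by a gap that lies beyond the usual scatter. The two differ in more than one place, so nothing more than these two values can be drawn from the pair.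

The step of interest leads from compound 1 to compound 3, `CC(C)C[C@H](NC(=O)CN(c1nc(Cl)nc2[nH]cnc12)C1CC1)C(=O)OCc1ccccc1`. The change is isopropyl in place of hydrogen on a saturated chain carbon, two bonds along the chain from an amide-type nitrogen and a carbonyl carbon. Nothing in this pair of measured compounds shows the effect of a change of this kind, so the direction of the step is open; a modest step in either direction, or none beyond the scatter, is the expectation. For compound 3 a value of 45% is estimated, within 20% to 70%, which corresponds to an expected step of a number 3.8 percentage points higher from compound 1 to compound 3 (within the scatter).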

Compound 3, a percentage reported as activity, at one dose (the size of the read-out at that dose, not a potency): 33.9%
Compound 3: middle estimate off by 11.1 percentage points, on the high side; the measured number falls inside the stated range.
By their numbers in this assay, from the lowest: compounds 3 and 1 (each within the scatter of the next); then compound 2.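

Within the data shown here, putting isopropyl in place of hydrogen on this saturated chain carbon gives a number 7.3 percentage points lower from compound 1 to compound 3 (within the scatter) in this assay, the first reading of a change at this position in the chain. At this one dose, then, the position takes isopropyl with no step beyond the scatter, something the earlier pair, which differs in more than one place, could not show. No measurement available here offers an explanation for this result.

Going by these compounds, it remains open whether a larger or differently built group at this carbon, such as a phenyl ring, a longer chain, an amine or a carboxylic acid, would also stay within the scatter. On these data alone, it is also open whether isopropyl would give a similar step on the core of compound 2, or at other doses.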